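From methoxy to 3-chloropropoxy: a tolerance estimate

This account rests on a few compounds, and the source may have more. Where it says the series, first, only, none or still open, it means among the compounds named here.

In a toxicity assay on Huh-7.5 cells (Homo sapiens) for inhibition, read by MTT assay, with a stated time of 96 h (a lower number here means that less compound is tolerated, a higher number that more compound is tolerated), compound 1 (`CN1CCN(Cc2ccc(NC(=O)c3ccc(OCCCCl)c(S(N)(=O)=O)c3)cc2C(F)(F)F)CC1`) gives 5470 nM, compound 2 (`CCC(=O)Nc1cc(C(=O)Nc2ccc(CN3CCN(C)CC3)c(C(F)(F)F)c2)ccc1OC(C)C`) gives 15300 nM, and compound 3 (`CCC(=O)Nc1cc(C(=O)Nc2ccc(CN3CCN(C)CC3)c(C(F)(F)F)c2)ccc1OC`) gives 35300 nM. That last number is the highest of the three, so compound 3 is the best tolerated so far.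

Compound 4 (`CCC(=O)Nc1cc(C(=O)Nc2ccc(CN3CCN(C)CC3)c(C(F)(F)F)c2)ccc1OCCCCl`) changes only the chain on the oxygen of compound 3: 2-chloroethyl in place of hydrogen on a saturated chain carbon bound to an oxygen on an aromatic ring. In words, 2-chloroethyl stands in place of hydrogen on a saturated chain carbon bound to an oxygen on an aromatic ring, which turns methoxy into 3-chloropropoxy.

One measured step changes the group at this oxygen: a 2.3-fold higher number from compound 2 to compound 3 (0.36 log units; beyond the scatter), with methyl in place of isopropyl. This modest step pairs methyl with the higher number, but a single pair is thin evidence. Compound 1 already carries a 3-chloropropoxy and gives 5470 nM, yet it also differs from compound 4 elsewhere, so it serves only as a rough guide.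

Taken together, these suggest that the move away from methyl should lower the number in this assay, by somewhat more than the one measured step. The expected step is a 3.5-fold lower number from compound 3 to compound 4 (0.55 log units; beyond the scatter). The estimated value for compound 4 is 10000 nM, with an expected range of 4500 nM to 22000 nM.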

Compound 4, half-maximal cytotoxic concentration: 7870 nM
The estimate for compound 4 lay 1.3-fold (0.10 log units) above the measured number, and the stated range covers the measured number.
By their numbers in this assay, from the lowest: compounds 1, 4 and 2 (each within the scatter of the next, the first and the last beyond it); then compound 3.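

In this assay, 3-chloropropoxy on the aromatic ring joins isopropoxy as a second group at this oxygen that gives a lower number than methoxy (a 4.5-fold lower number from compound 3 to compound 4 (0.65 log units; beyond the scatter)), so among compounds 2, 3 and 4 the methoxy compound stands highest. The two non-methyl groups cannot be told apart, however: the step (a 1.9-fold lower number from compound 2 to compound 4 (0.29 log units; within the scatter)) lies within the scatter, so the branched isopropyl and the straight 3-chloropropyl chain give numbers that this assay does not separate. The other part of the molecule can now be read with 3-chloropropoxy held fixed, and putting propanoylamino in place of sulfamoyl (a 1.4-fold higher number from compound 1 to compound 4 (0.16 log units; within the scatter)) also stays within the scatter, so this one swap shows no readable change in tolerance.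

The compounds shown leave open whether the chlorine or the chain itself goes with the lower number, a question that a plain propyl chain or a 3-hydroxypropyl chain on the same oxygen would address. Nothing shown here bears on why the number differs at this position.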